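This account rests on a few compounds, and the source may have more. Where it says the series, first, only, none or still open, it means among the compounds named here.

Three compounds have been measured in an assay on isolated protein for displacement of a labelled ligand from metabotropic glutamate receptor 5 (Homo sapiens), with a stated time of 60 min, tested at 1 uM; on this read-out higher numbers stand for more inhibition at the one concentration tested (going by the name of the read-out) and lower numbers for less inhibition:

compound 1 `Cc1ccc(S(=O)(=O)c2cnc3ccc(F)cc3c2N2CCC(C)CC2)cc1` gives 91%
compound 2 `CC1CCN(c2c(S(=O)(=O)c3cc(Cl)cc(Cl)c3)cnc3c(F)cccc23)CC1` gives 82%
compound 3 `CC1CCN(c2c(S(=O)(=O)c3ccccc3)cnc3cc(Cl)ccc23)CC1` gives 93%

All three share the same core and carry a 4-methylpiperidine on it; they differ in the ring attached to the sulfonyl sulfur and in the halogen on the core. In this assay the three numbers sit close together: compound 1 lies within the usual scatter of compound 3 and also of compound 2, so the data do not separate any of them. Compound 4 `Cc1cc(C)cc(S(=O)(=O)c2cnc3ccc(F)cc3c2N2CCC(C)CC2)c1` has not yet been measured. It is compound 1 with one change: 3,5-dimethylphenyl in place of 4-methylphenyl on a sulfonyl sulfur. Within the data shown here, the three measured compounds show that several different rings on the sulfonyl sulfur all give high numbers in this assay, but no pair of them isolates this particular change. With nothing pointing the other way, the step from compound 1 to compound 4 in this assay is expected to stay within the scatter, with a small downward lean. Compound 4 is estimated at 85%, between 65% and 96%, an expected step of a number 6 percentage points lower from compound 1 to compound 4 (within the scatter).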

Compound 4, a percentage reported as inhibition, at one concentration (the size of the read-out at that concentration, not a potency): 83%
Beside the measured number, compound 4's estimate is 2 percentage points above it, within the range that was stated.
By their numbers in this assay, from the lowest: compounds 2, 4, 1 and 3 (each within the scatter of the next, the first and the last beyond it).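

Among these compounds, compound 1 and compound 4 form the first pair that isolates a change on the sulfonyl sulfur, with the shared core, the fluorine and the 4-methylpiperidine all held the same. In this assay, putting 3,5-dimethylphenyl in place of 4-methylphenyl gives a number 8 percentage points lower from compound 1 to compound 4 (within the scatter), so the assay does not separate the two compounds, and this position accepts a ring with one more carbon while the number stays high. Nothing available explains the size of this step.

The compounds shown leave open whether the ring on the sulfonyl sulfur could carry an amine or a carboxylic acid in place of a methyl and still give a high number. A reading at a single concentration also cannot say whether compound 1 and compound 4 differ in potency.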